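Working notes: from compound 3 to compound 4

The compounds below may be only part of what the source reports. "The series", "measured", "known", "first", "only" and "open" are said of these compounds alone.

Measured in a functional assay on the whole organism for inhibition, with Chenopodium ficifolium as the target, with a stated time of 72 h, tested at 100 mg/L; on this read-out higher numbers stand for more inhibition of growth at the one concentration tested and lower numbers for less inhibition of growth:
compound 1 `COc1cc(SC)nc(NC(=S)NC(=O)c2c(-c3ccc(Cl)cc3Cl)noc2C)n1` gives 60.3%
compound 2 `CSc1cc(C)nc(NC(=S)NC(=O)c2c(-c3ccc(Cl)cc3Cl)noc2C)n1` gives 86.1%
compound 3 `Cc1cc(Cl)nc(NC(=S)NC(=O)c2c(-c3ccc(Cl)cc3Cl)noc2C)n1` gives 48.3%

Compound 3 stands lowest of the three: a number 12 percentage points lower from compound 1 to compound 3 (beyond the scatter), and a number 37.8 percentage points lower from compound 2 to compound 3 (beyond the scatter). Compound 4 `COc1cc(OC)nc(NC(=S)NC(=O)c2c(-c3ccc(Cl)cc3Cl)noc2C)n1` is not yet measured; it carries 4,6-dimethoxypyrimidin-2-yl in place of 4-chloro-6-methylpyrimidin-2-yl on an amide-type nitrogen. Within the data shown here, two measured steps bear on it. The exchange of the ring as a whole, a number 12 percentage points lower from compound 1 to compound 3 (beyond the scatter), ran counter to the direction now taken, so reversing it would be expected to raise the number modestly. Within that ring, a number 25.8 percentage points higher from compound 1 to compound 2 (beyond the scatter), so the opposite exchange, methoxy in place of methyl, would be expected to lower it. Methoxy in place of chloro has no measured counterpart here. On balance a modest rise from compound 3 is expected, a number 6.7 percentage points higher from compound 3 to compound 4 (within the scatter). For compound 4 in this assay the expected value is 55%, between 35% and 75%.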

Compound 4, percent growth inhibition at one concentration: 78.6%
Beside the measured number, compound 4's estimate is 23.6 percentage points below it; measured number outside the range, above it.
By their numbers in this assay, from the lowest: compound 3; then compound 1; then compounds 4 and 2 (each within the scatter of the next).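

At this position on an amide-type nitrogen, the low number of compound 3 is not general to the ring: 4,6-dimethoxypyrimidin-2-yl in place of 4-chloro-6-methylpyrimidin-2-yl recovers much of the read-out in this assay (a number 30.3 percentage points higher from compound 3 to compound 4 (beyond the scatter)). The second methoxy also gives a number level with the methyl and methylsulfanyl pairing (a number 7.5 percentage points lower from compound 2 to compound 4 (within the scatter)). Methoxy in place of methylsulfanyl (a number 18.3 percentage points higher from compound 1 to compound 4 (beyond the scatter)) shows that the outcome of a methoxy group depends on its partner on the ring, in compounds 1, 2 and 4.

Nothing at hand accounts for these steps. From the compounds shown here alone, how an amino or ethoxy group would read at this ring remains open.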